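A few compounds are considered here, and "the series" means these few. Any claim that something is new, unique, unknown or untested is made for them only; others in the source may bear on it.

Working notes on the series. Compound 1 `Cc1ccc(NC(=O)NC(=O)c2ccc(OCc3cccc(C(F)(F)F)c3)cc2)cc1-c1nc2ccccc2[nH]1` and compound 2 `Cc1ccc(NC(=O)NC(=O)c2ccc(OCc3cccc(F)c3)cc2)cc1-c1nc2ccccc2[nH]1` share one core and differ only in the group on the benzyl ring. In a functional assay on HT-29 cells (Homo sapiens) for inhibition, read by MTT assay, with a stated time of 48 h (a lower number here means a stronger inhibitor, a higher number a weaker inhibitor), compound 1 gives 3520 nM, while compound 2 gives 38200 nM. Among the measured compounds shown here, compound 2 thus stands at the highest of the two numbers measured so far; its nearest neighbour is compound 1, and the step of an 11-fold higher number from compound 1 to compound 2 (1.04 log units; beyond the scatter) is large and beyond the scatter.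

Compound 3 `Cc1ccc(NC(=O)NC(=O)c2ccc(OCc3ccccc3Cl)cc2)cc1-c1nc2ccccc2[nH]1` is not yet measured. It differs from compound 2 by 2-chlorophenyl in place of 3-fluorophenyl on a saturated chain carbon bound to an oxygen on an aromatic ring. For the measured compounds named here, only one measured step exists, the step from compound 1 to compound 2, and it concerns a different change on the same benzyl group; it shows that changes there can move the number by a large amount, but it does not cover the change to 2-chlorobenzyl. Going by the values given here, no measured step bears directly on this change. The direction is therefore open, and the expectation is worded loosely. For compound 3 the expected step is a 2.5-fold lower number from compound 2 to compound 3 (0.41 log units; beyond the scatter), a decrease set between no change and the size seen for the other benzyl change. Compound 3 is accordingly estimated at 15000 nM, with a range from 4000 nM to 60000 nM.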

Compound 3, half-maximal inhibitory concentration: 9010 nM
Estimate against measurement, compound 3: 1.7-fold (0.22 log units) above, and the stated range covers the measured number.
By their numbers in this assay, from the lowest: compound 1; then compound 3; then compound 2.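

In this assay the exchange of 3-fluorophenyl for 2-chlorophenyl on a saturated chain carbon bound to an oxygen on an aromatic ring gives a 4.2-fold lower number from compound 2 to compound 3 (0.63 log units; beyond the scatter) and so recovers part of the loss seen earlier on this benzyl group. The exchange of 3-(trifluoromethyl)phenyl for 2-chlorophenyl at the same place gives a 2.6-fold higher number from compound 1 to compound 3 (0.41 log units; beyond the scatter) as its step, which leaves compound 3 in the middle of the series, so this position now shows three separate levels rather than a single large drop, with compound 1 still giving the lowest number. No measurement at hand accounts for these differences.

The step to compound 3 changes both the halogen and its place on the ring, so the compounds shown cannot separate the contribution of either, and they do not tell whether the trend depends on the halogen, on where it sits or on both. Going by these compounds, how an amine or a carboxylic acid on this benzyl ring would behave also stays open, as does whether the order of the three compounds would hold in other cell lines.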